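The compounds below may be only part of what the source reports. "The series", "measured", "known", "first", "only" and "open" are said of these compounds alone.

Compound 1 `NCC(=O)NCc1nnc(-c2ccccc2)o1`: 155 nM
Compound 2 `NCC(=O)NCc1nnc(-c2ccc(F)cc2)o1`: 135 nM

In an assay for inhibition of histone deacetylase 8 (Homo sapiens), read by fluorescence, with a stated time of 15 min (a lower number here means a stronger inhibitor, a higher number a weaker inhibitor), compound 2 gives 135 nM. Compound 1 gives 155 nM, and the step between the two, a 1.1-fold lower number from compound 1 to compound 2 (0.06 log units; within the scatter), lies within the scatter, so compound 2 does not stand apart from compound 1 on these numbers. Compound 3 `Cc1ccc(-c2nnc(CNC(=O)CN)o2)cc1` differs from compound 2 by methyl in place of fluoro on an aromatic carbon. Among the compounds with values here, the only measured step touches the same aromatic carbon and was within the scatter; no measured step compares methyl with fluoro. A change no larger than the scatter is therefore expected, a 1.0-fold higher number from compound 2 to compound 3 (0.02 log units; within the scatter). Compound 3 is estimated at 140 nM, in a range from 70 nM to 280 nM.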

Compound 3, half-maximal inhibitory concentration: 139 nM
The estimate for compound 3 lay 1.0-fold (0.00 log units) above the measured number; the range from low to high includes it.
By their numbers in this assay, from the lowest: compounds 2, 3 and 1 (each within the scatter of the next).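

In this assay, within the data shown here, the aromatic carbon para to a large group now carries methyl as well as fluoro and hydrogen, and the first direct comparison of methyl with fluoro gives a 1.0-fold higher number from compound 2 to compound 3 (0.01 log units; within the scatter), while methyl against hydrogen gives a 1.1-fold lower number from compound 1 to compound 3 (0.05 log units; within the scatter). Both steps lie within the scatter, so none of the three groups stands apart at this position. No measured evidence bears on this result. The compounds shown leave open whether an amine, a carboxylic acid or a longer chain at this carbon would give a step beyond the scatter.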